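Hydrogen to methyl on compound 1

The source may hold more compounds than are shown below. What is called first, only, known or untested is meant among the compounds shown, and "the series" means these compounds.

Among the measured compounds shown here, in a functional assay on A549 cells (Homo sapiens) for cytotoxicity, read by MTT assay, with a stated time of 72 h (a higher number here means a weaker inhibitor, a lower number a stronger inhibitor), compound 1 `O=C1C(Nc2ccccc2)=CC(=O)c2ncncc21` gives 0.02 ug/mL, the lower of the two numbers measured so far. Compound 2 `O=C1C(Nc2ccc(Br)cc2)=CC(=O)c2ncncc21` gives 0.09 ug/mL in this assay. Compound 3 `Cc1ccc(NC2=CC(=O)c3ncncc3C2=O)cc1` has yet to be measured there. It differs from compound 1 by methyl in place of hydrogen on an aromatic carbon, para to a large group: methyl in place of hydrogen on an aromatic carbon.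

For the measured compounds named here, only one measured step bears on this change. Bromo in place of hydrogen on an aromatic carbon gave a 4.5-fold higher number from compound 1 to compound 2 (0.65 log units; beyond the scatter), a modest step beyond the scatter. Going by the values given here, this is thin ground, since it is a single step and no methyl compound has yet been measured. Among the compounds with values here, with only that precedent, the same direction is expected for methyl, towards a higher number and so a weaker inhibitor, though perhaps by a smaller amount. The expected step is a 2.5-fold higher number from compound 1 to compound 3 (0.40 log units; beyond the scatter), which may not clear the scatter. For compound 3 the estimated value is 0.05 ug/mL, with an expected range of 0.02 ug/mL to 0.15 ug/mL.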

Compound 3, half-maximal inhibitory concentration: 0.02 ug/mL
For compound 3 the middle estimate is 2.5-fold (0.40 log units) above the measured one, and the stated range covers the measured number.
By their numbers in this assay, from the lowest: compounds 1 and 3 (each within the scatter of the next); then compound 2.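

In this assay, the place para to a large group on the six-membered aromatic ring of carbon only can now be read with a second substituent: methyl in place of hydrogen shows no change at the digits printed from compound 1 to compound 3 (within the scatter) and so leaves compounds 1 and 3 within the scatter of each other. The bromo step alone could not show that a group here need not come with a higher number, but methyl in place of bromo gives a 4.5-fold lower number from compound 2 to compound 3 (0.65 log units; beyond the scatter) and so ties the higher number of compound 2 to bromo among the groups shown, not to any substituent at this place. Nothing measured here explains why bromo and methyl part in this way.

The compounds shown leave open where a longer alkyl chain, a methoxy group, an amine or a carboxylic acid would fall at this place, and whether any of them would stay with compounds 1 and 3 or join compound 2. They also leave open whether chloro or fluoro would follow bromo, which would test whether the higher number extends to other halogens.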